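Aryl ether ureas: growth inhibition of MCF7 cells

The compounds below may be only part of what the source reports. "The series", "measured", "known", "first", "only" and "open" are said of these compounds alone.

Measured so far:
compound 1 `O=C(CCl)NC(=O)Nc1ccc(OC2CCCCCC2)cc1` gives 3600 nM in a functional assay on MCF7 cells (Homo sapiens) for inhibition, read by sulforhodamine B assay, with a stated time of 48 h; a higher number here means a weaker inhibitor of growth, a lower number a stronger inhibitor of growth
compound 2 `O=C(CCl)NC(=O)Nc1cccc(OC2CCCCCC2)c1` gives 7200 nM in this assay
compound 3 `O=C(CCl)NC(=O)Nc1ccc(Oc2ccccc2)cc1` gives 4200 nM in this assay

The three values lie within the scatter of one another, so no order among them is claimed. Compound 1 and compound 2 share the same atoms joined differently; the difference between the two cores is not broken down here. Compound 3 is made from compound 1 by phenyl in place of cycloheptyl on an oxygen on an aromatic ring, and that change gave a 1.2-fold higher number from compound 1 to compound 3 (0.07 log units; within the scatter).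

Compound 4 `O=C(CCl)NC(=O)Nc1cccc(Oc2ccccc2)c1` is not yet measured. It arises from compound 2 by phenyl in place of cycloheptyl on an oxygen on an aromatic ring, the same change at the same place. For compound 4 the expected step is a 1.2-fold higher number from compound 2 to compound 4 (0.07 log units; within the scatter), resting on the step seen from compound 1 to compound 3, a 1.2-fold higher number from compound 1 to compound 3 (0.07 log units; within the scatter), with one prior example only. Compound 4 is thus estimated at 8500 nM, expected between 4000 nM and 18000 nM in this assay.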

Compound 4, concentration for 50% growth inhibition: 8100 nM
Estimate against measurement, compound 4: 1.0-fold (0.02 log units) above, within the range that was stated.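

Phenyl in place of cycloheptyl on an oxygen on an aromatic ring gave a 1.1-fold higher number from compound 2 to compound 4 (0.05 log units; within the scatter) in this assay. Set beside the earlier step, the change carried from one core to the other with no difference that can be read: the same change on two cores in this assay, a 1.2-fold higher number (0.07 log units; within the scatter) from compound 1 to compound 3 and a 1.1-fold higher number (0.05 log units; within the scatter) from compound 2 to compound 4, 1.0-fold (0.02 log units) apart, within the scatter of two such steps

Neither step lies beyond the scatter, so this does not show that either group is the better one, and two cores say nothing about any other core in the series.

Still open, from the compounds shown here alone, is whether a group other than these two on the oxygen, such as methyl or pyridyl, would give a step beyond the scatter. All the compounds shown carry the chloroacetyl group, so what an acetyl group there would give also remains open.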